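Acetylating the hydroxy group of compound 3

The compounds below may be only part of what the source reports. "The series", "measured", "known", "first", "only" and "open" are said of these compounds alone.

Values in a functional assay on HL-60 cells (Homo sapiens) for cytotoxicity, read by XTT assay, with a stated time of 72 h; on this read-out lower numbers stand for stronger inhibition and higher numbers for weaker inhibition:
- compound 1 `CCn1ccc2cc(C(O)c3cc(OC)c(OC)c(OC)c3)ccc21`: > 10000 nM (a limit)
- compound 2 `COc1cc(C(OC(C)=O)c2ccc3c(ccn3C)c2)cc(OC)c1OC`: 240 nM
- compound 3 `CCn1ccc2cc(/C(=N\O)c3cc(OC)c(OC)c(OC)c3)ccc21`: > 1000 nM (a limit)

Compound 3 stands at > 1000 nM, which is a limit of the assay and not a number. Compound 1 also gives only a limit, > 10000 nM. Compound 2 is the only one of the three with a true number, 240 nM.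

The next compound, compound 4 `CCn1ccc2cc(/C(=N\OC(C)=O)c3cc(OC)c(OC)c(OC)c3)ccc21`, changes compound 3 in one place: acetyl in place of hydrogen on an oxygen. In words, acetyl takes the place of hydrogen on an oxygen whose other neighbour is a double-bonded nitrogen, so hydroxy becomes acetoxy.

Within the data shown here, no measured pair shows this change alone, so any forecast rests on thin ground. Compound 2 also carries an acetoxy group and gives 240 nM, which points to a possible gain. In this assay a fall in the number beyond the usual scatter is therefore expected, toward stronger inhibition. Its size stays loose, since compound 3 offers no exact starting point. The expected change is an at least 2.5-fold lower number from compound 3 to compound 4 (0.39 log units; beyond the scatter). For compound 4 the estimated value is 400 nM, with an expected range of 80 nM to 2000 nM.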

Compound 4, half-maximal inhibitory concentration: > 1000 nM
Compound 4: no number, only a limit; the forecaster's own chance of this, stated with the estimate: 30%; at least 2.5-fold (0.39 log units) between middle value and limit.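

Compound 3 and compound 4 each give only a limit of the assay and not a number, so no step from one to the other can be read: the limit of > 1000 nM in this assay, at which 2 of the 4 values shown sit.

The compounds shown leave open whether acetoxy in place of hydroxy changes the inhibition at all, and if it does, in which direction and by how much.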